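The source may report more compounds than this note shows. Statements on the series, on what has been measured and on what is new or still open speak of the compounds shown alone.

Of the compounds shown here, two have been tested so far in a toxicity assay on L02 cells (Homo sapiens) for cytotoxicity, read by MTT assay, with a stated time of 72 h; a lower number here means a stronger inhibitor, a higher number a weaker inhibitor. Compound 1, `CC1(C)O[C@@H](CO)[C@H](Cn2cc(Cn3c4c(c5ccccc53)C(=O)c3c[n+]([O-])c5ccccc5c3C4=O)nn2)O1`, gives 500 nM. Compound 2, `CN(C)CCCCn1c2c(c3ccccc31)C(=O)c1c[n+]([O-])c3ccccc3c1C2=O`, gives 300 nM. These two differ in more than one place, so only the bare numbers can be compared: the two sit within the usual scatter of each other, and nothing separates them in this assay.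

Compound 3, `CC1(C)OC[C@@H](Cn2cc(Cn3c4c(c5ccccc53)C(=O)c3c[n+]([O-])c5ccccc5c3C4=O)nn2)O1`, has not yet been measured. It differs from compound 1 in a single place: 2,2-dimethyl-1,3-dioxolan-4-yl in place of 5-(hydroxymethyl)-2,2-dimethyl-1,3-dioxolan-4-yl on a saturated chain carbon bound to an aromatic nitrogen. The shared core of compound 1 is untouched, and only the ring carried on the chain that hangs from the aromatic nitrogen loses one group.

For the measured compounds named here, no pair of measured compounds shows what such a change does in this assay, so the expectation rests on the change itself. Since the core and the chain stay as they are, compound 3 is expected to sit close to compound 1, with a step that stays within the scatter, a 1.1-fold lower number from compound 1 to compound 3 (0.05 log units; within the scatter). Compound 3 is therefore estimated at 450 nM, with a range from 200 nM to 1000 nM.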

Compound 3, half-maximal inhibitory concentration: 2900 nM
For compound 3 the middle estimate is 6.4-fold (0.81 log units) below the measured one; measured number outside the range, above it.
By their numbers in this assay, from the lowest: compounds 2 and 1 (each within the scatter of the next); then compound 3.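

In this assay, taking the hydroxymethyl group off the ring carried on the saturated chain carbon gives a 5.8-fold higher number from compound 1 to compound 3 (0.76 log units; beyond the scatter), so this one small edit is enough to move the number beyond the scatter. The earlier pair differed in more than one place and could not show whether this ring's substituents matter at all; this pair shows that they do, with the hydroxymethyl-bearing compound 1 being the stronger inhibitor of these cells. No measurement at hand gives a reason for this shift.

The change removes the hydroxymethyl group and at the same time lowers the counts of hydrogen-bond donors, hydrogen-bond acceptors and defined stereocentres, so this single pair cannot tell which of these differences goes with the higher number. The compounds shown also leave open whether a methoxymethyl group or a carboxylic acid in place of the hydroxymethyl would keep the number near that of compound 1 or move it further, and whether the same step would appear on a different core.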